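Imidazopyrazine-benzimidazole series: aryl variation and M14 inhibition

A few compounds are considered here, and "the series" means these few. Any claim that something is new, unique, unknown or untested is made for them only; others in the source may bear on it.

Measured so far:
compound 1, `O=Cc1ccc(-c2cn3ccnc3c(-c3ccc4ncn(C5CCCCC5)c4c3)n2)cc1`: 23%
compound 2, `CC(=O)c1ccc(-c2cn3ccnc3c(-c3ccc4ncn(C5CCCCC5)c4c3)n2)cc1`: 3.43%

In a functional assay on M14 cells (Homo sapiens) for inhibition, read by sulforhodamine B assay, with a stated time of 48 h, tested at 10 uM (a lower number here means less inhibition, a higher number more inhibition at the concentration tested (going by the name of the read-out)), compound 2 stands lowest of the two numbers, with compound 1 the nearer and higher one. Going by the values given here, the one step within the pair, a number 19.6 percentage points lower from compound 1 to compound 2 (beyond the scatter), is the only measured change on the series and concerns the carbonyl substituent alone.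

Compound 3, `COc1ccccc1-c1cn2ccnc2c(-c2ccc3ncn(C4CCCCC4)c3c2)n1`, has not been measured in this assay. It differs from compound 2 as follows: 2-methoxyphenyl in place of 4-acetylphenyl on an aromatic carbon. Among the compounds with values here, no measured step replaces the whole aryl group, so the single known step gives no direct guide; it only shows that a change at this position can move the read-out by a modest amount. The step of a number 6.6 percentage points higher from compound 2 to compound 3 (within the scatter) is therefore expected to be small, with the direction uncertain and possibly within the scatter. For compound 3 the expected value is 10%, in the range -5% to 30%.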

Compound 3, a percentage reported as inhibition, at one concentration (the size of the read-out at that concentration, not a potency): 1.12%
Beside the measured number, compound 3's estimate is 8.9 percentage points above it; the range from low to high includes it.
By their numbers in this assay, from the lowest: compounds 3 and 2 (each within the scatter of the next); then compound 1.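

In this assay, replacing the whole aryl group on this aromatic carbon gives a number 2.3 percentage points lower from compound 2 to compound 3 (within the scatter), so a change far larger than the earlier methyl step leaves 2-methoxyphenyl and 4-acetylphenyl indistinguishable here. Against 4-formylphenyl, the same 2-methoxyphenyl gives a number 21.9 percentage points lower from compound 1 to compound 3 (beyond the scatter), which leaves compound 1 apart from both other compounds and shows that an aryl group without a carbonyl does not bring the number back to that of compound 1. Nothing on hand gives a cause for either step.

Still open, on these data alone, is whether the number of compound 1 is particular to 4-formylphenyl, or whether a carboxylic acid, a nitrile or an amine on the same aryl ring would stand with compound 1. Also open, as far as these compounds go, is how an unsubstituted phenyl would compare with these three compounds.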